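A fluoro for a hydroxy, with all values at a limit

The compounds below may be only part of what the source reports. "The series", "measured", "known", "first", "only" and "open" are said of these compounds alone.

Compound 1 `O=S(=O)(Nc1ccc(-c2nc3ccccc3o2)cc1)c1ccccc1O`: in an ADME assay on HEK293 cells (Homo sapiens) for cytotoxicity, read by resazurin assay, with a stated time of 48 h (on this read-out higher numbers stand for lower toxicity in this test and lower numbers for higher toxicity in this test), compound 1 gives a limit, > 100000 nM.
Compound 2 `O=S(=O)(Nc1ccc2oc(-c3ccccc3)nc2c1)c1cccc(C(F)(F)F)c1`: in this assay compound 2 gives a limit, > 100000 nM.
Compound 3 `O=S(=O)(Nc1ccc2oc(-c3ccccc3)nc2c1)c1ccc(F)c(C(F)(F)F)c1`: in this assay compound 3 gives a limit, > 100000 nM.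

Compound 1 stands, like the other two, at a limit of the test rather than at a number; all three values sit at the limit of > 100000 nM in this assay, at which 3 of the 3 values shown sit. Compound 4 `O=S(=O)(Nc1ccc(-c2nc3ccccc3o2)cc1)c1ccccc1F` has not yet been measured. It differs from compound 1 in one place: fluoro in place of hydroxy on an aromatic carbon. The only measured step among these compounds, a step that the two limits leave unreadable from compound 2 to compound 3, swaps a fluoro for a hydrogen on an aromatic carbon, and since both of its ends are limits its size cannot be read. No measured step therefore speaks directly to the change from a hydroxy to a fluoro, and the evidence gives no reason to expect any movement beyond the scatter.

For compound 4 the estimate is 100000 nM, with a range from 50000 nM to 200000 nM. The step this estimate means, a number no higher from compound 1 to compound 4 (the limit leaves the size open), is expected to be none beyond the scatter, and the most likely outcome is that compound 4, too, is reported only as a limit.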

Compound 4, half-maximal cytotoxic concentration: > 100000 nM
Compound 4: only a limit was reported; the forecaster's own chance of this, stated with the estimate: 85%; the middle value lies on the limit itself.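

In this assay, among these compounds, compound 1 and compound 4 are each reported only as a limit, so no step between them can be read. All the values shown stand at the same place: the limit of > 100000 nM in this assay, at which 4 of the 4 values shown sit.

The compounds shown leave open how far any of them lies from that limit, and whether fluoro in place of hydroxy shifts the read-out at all.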